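Aryl-group variation on the shared core, acid dissociation

The compounds below may be only part of what the source reports. "The series", "measured", "known", "first", "only" and "open" are said of these compounds alone.

Of the compounds shown here, three on the shared core have been measured in a physicochemical assay for acid dissociation. Compound 1 `CN(C)c1cccc(Oc2ccc3c(NCCCNCc4ccco4)ccnc3c2)c1` gives 9.28. Compound 2 `CCC(CC)c1ccc2c(NCCCNCc3ccco3)ccnc2c1` gives 9.47. Compound 3 `c1ccc(Cc2ccc3c(NCCCNCc4ccco4)ccnc3c2)cc1` gives 9.47. Compound 3 is level with compound 2 at the digits shown, the two together the highest of the three numbers, and compound 1 sits closest below within the scatter. The measured steps are a number 0.19 log units higher from compound 1 to compound 2 (within the scatter), a number 0.19 log units higher from compound 1 to compound 3 (within the scatter) and no change at the digits printed from compound 2 to compound 3 (within the scatter): every exchange at this aromatic carbon has left the read-out where it was.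

Compound 4 `COc1ccc(-c2ccc3c(NCCCNCc4ccco4)ccnc3c2)cc1` is not yet measured in this assay. Its change from compound 3 is 4-methoxyphenyl in place of benzyl on an aromatic carbon. All three measured steps bear on it, since each also exchanges the group on the same aromatic carbon, and none of them moved the number beyond the scatter. The expected step in this assay is therefore none beyond the scatter, which as an estimate is a number 0.02 log units lower from compound 3 to compound 4 (within the scatter). Compound 4 is expected to give 9.45, with a range from 9.15 to 9.75.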

Compound 4, acid dissociation constant: 9.47
Compound 4: middle estimate off by 0.02 log units, on the low side; the range from low to high includes it.
By their numbers in this assay, from the lowest: compounds 1, 2, 3 and 4 (each within the scatter of the next).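

In this assay, 4-methoxyphenyl in place of benzyl gives no change at the digits printed from compound 3 to compound 4 (within the scatter), although the entering group carries one hydrogen-bond acceptor and the leaving group none. The same group set against the other two substituents gives no change at the digits printed from compound 2 to compound 4 (within the scatter) and a number 0.19 log units higher from compound 1 to compound 4 (within the scatter), so the four groups on this aromatic carbon now stand within the scatter of one another, and no compound shown goes against that. Nothing available explains this flat result.

Going by these compounds, whether a carboxylic acid or a primary amine on this aromatic carbon would move the number beyond the scatter remains open. All four compounds also keep the rest of the shared core unchanged, so the effect of a longer or shorter chain elsewhere on the core cannot be judged from them.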